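Moving the Methoxy Group on the Anilino Ring

A few compounds are considered here, and "the series" means these few. Any claim that something is new, unique, unknown or untested is made for them only; others in the source may bear on it.

Compound 1 `C#CCSc1nc(Nc2cccc(Cl)c2)c(C#N)c(-c2ccccc2)n1`: in a functional assay on ECa-109 cells (Homo sapiens) for inhibition, read by MTT assay, with a stated time of 72 h (a higher number here means a weaker inhibitor, a lower number a stronger inhibitor), compound 1 gives only a limit, > 128000 nM.
Compound 2 `COc1ccc(Nc2nc(SCc3cn(Cc4ccccc4Cl)nn3)nc(-c3ccccc3)c2C#N)cc1`: in this assay compound 2 gives 7960 nM.

Within the data shown here, compound 2 holds the only number reported here; the other value is a limit, as the limit of > 128000 nM in this assay, at which 1 of the 2 values shown sits, records. Compound 3 `COc1ccccc1Nc1nc(SCc2cn(Cc3ccccc3Cl)nn2)nc(-c2ccccc2)c1C#N` differs from compound 2 by 2-methoxyphenyl in place of 4-methoxyphenyl on a nitrogen on an aromatic ring. Among the measured compounds shown here, no measured pair shows this change, so the expected step is small, within the usual scatter, with a slight lean toward weaker inhibition. For compound 3 the expected value in this assay is 12000 nM, ranging from 4000 nM to 40000 nM. The estimated step is a 1.5-fold higher number from compound 2 to compound 3 (0.18 log units; within the scatter).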

Compound 3, half-maximal inhibitory concentration: 9670 nM
Beside the measured number, compound 3's estimate is 1.2-fold (0.09 log units) above it; low and high end bracket the measured number.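

Among these compounds, this is the first direct comparison at this position, and moving the methoxy group gives, in this assay, a 1.2-fold higher number from compound 2 to compound 3 (0.08 log units; within the scatter). The two placements, 4-methoxyphenyl and 2-methoxyphenyl on the nitrogen, therefore cannot be told apart in this assay, so compound 2 and compound 3 read as equals. Nothing measured here bears on why the two read alike.

Only the place of the methoxy group has been varied on this ring. From the compounds shown here alone, whether an amine or a carboxylic acid in its stead would change the number remains open.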